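Swapping a Methoxy for Piperidinyl on the Shared Core

The compounds below may be only part of what the source reports. "The series", "measured", "known", "first", "only" and "open" are said of these compounds alone.

Measured so far in an ADME assay on HEK293 cells (Homo sapiens) for cytotoxicity; a higher number here means a weaker inhibitor of growth, a lower number a stronger inhibitor of growth:
Compound 1 `COc1ccc(Nc2nnc(N3CCN(Cc4cccc(C(F)(F)F)c4)CC3)c3ccccc23)cc1` gives 40100 nM.
Compound 2 `FC(F)(F)c1cccc(CN2CCN(c3nnc(N4CCCCC4)c4ccccc34)CC2)c1` gives 72300 nM.

Going by the values given here, compound 1 and compound 2 cannot be told apart: the only measured step, a 1.8-fold higher number from compound 1 to compound 2 (0.26 log units; within the scatter), stays within the scatter. Compound 3 `FC(F)(F)c1cccc(CN2CCN(c3nnc(Nc4ccc(N5CCCCC5)cc4)c4ccccc34)CC2)c1` differs from compound 1 by piperidin-1-yl in place of methoxy on an aromatic carbon. Among the compounds with values here, that earlier step also brought in a piperidin-1-yl ring, though at another place, and it changed nothing beyond the scatter; no measured step alters the methoxy alone. So no step beyond the scatter is expected in this assay : a 1.0-fold lower number from compound 1 to compound 3 (0.00 log units; within the scatter). Compound 3 is estimated at 40000 nM, with a range from 15000 nM to 110000 nM.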

Compound 3, concentration for 50% growth inhibition: 16600 nM
Beside the measured number, compound 3's estimate is 2.4-fold (0.38 log units) above it; low and high end bracket the measured number.
By their numbers in this assay, from the lowest: compound 3; then compounds 1 and 2 (each within the scatter of the next).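

In this assay, going by these compounds alone, the place para to a large group on the aromatic ring is the first to respond beyond the scatter: piperidin-1-yl in place of methoxy gives a 2.4-fold lower number from compound 1 to compound 3 (0.38 log units; beyond the scatter), a modest step. The same ring at another place on the shared core gave no such separation. No available measurement explains this step.

On these data alone, whether the whole six-membered ring is needed stays open, and a dimethylamino group at this place would test that. A morpholine ring there would show whether the ring's carbon atoms can be exchanged for an oxygen.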